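A few compounds are considered here, and "the series" means these few. Any claim that something is new, unique, unknown or untested is made for them only; others in the source may bear on it.

Measured compounds:
- compound 1 `O=C(Nc1cccc(-n2cc(-c3ccncc3)c(-c3ccc(Cl)c(O)c3)n2)c1)Nc1cccc(C(F)(F)F)c1`; in a functional assay on OVCAR-3 cells (Homo sapiens) for inhibition, read by sulforhodamine B assay, with a stated time of 48 h (on this read-out higher numbers stand for lower toxicity in this test and lower numbers for higher toxicity in this test), compound 1 gives > 32500 nM, which is a limit of the assay and not a number.
- compound 2 `O=C(Nc1cccc(-n2cc(-c3ccncc3)c(-c3ccc(Cl)c(O)c3)n2)c1)Nc1ccc(Cl)c(Cl)c1`; in this assay compound 2 gives > 32500 nM, again a limit of the assay.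
- compound 3 `COc1cc(-c2nn(-c3cccc(NC(=O)Nc4cccc(C(F)(F)F)c4)c3)cc2-c2ccncc2)ccc1Cl`; in this assay compound 3 gives 24700 nM.

Compound 1 therefore stands at the limit, the place where most of this small set sits: the limit of > 32500 nM in this assay, at which 2 of the 3 values shown sit. The unmeasured compound 4 `O=C(Nc1cccc(-n2cc(-c3ccncc3)c(-c3ccc(Cl)c(O)c3)n2)c1)Nc1cc(C(F)(F)F)cc(C(F)(F)F)c1` differs from compound 1 in a single place: trifluoromethyl in place of hydrogen on an aromatic carbon. Two measured steps start from compound 1. The first, a step that the two limits leave unreadable from compound 1 to compound 2, cannot be read because both ends are limits. The second, an at least 1.3-fold lower number from compound 1 to compound 3 (0.11 log units; that floor lies within the scatter), is small and lies within the scatter. Neither step touches the same ring position as the change toward compound 4, and neither shows any movement beyond the scatter, so no step beyond the scatter is expected in this assay, and the most probable outcome is another limit. Compound 4 is accordingly estimated at 32500 nM, within 15000 nM to 65000 nM, which corresponds to an expected step of a number no higher from compound 1 to compound 4 (the limit leaves the size open).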

Compound 4, concentration lethal to 50% of the cells: 3310 nM
Compound 4: middle estimate off by 9.8-fold (0.99 log units), on the high side, outside the stated range (below it).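

In this assay, within the data shown here, this position responds where the earlier changes showed nothing readable: trifluoromethyl in place of hydrogen on an aromatic carbon, meta to a trifluoromethyl group, gives an at least 9.8-fold lower number from compound 1 to compound 4 (0.99 log units; beyond the scatter) and is the first change here to move the value beyond the scatter. Going by these compounds, compound 1 stands at a limit, so this step is only a floor and its full size stays open. The step to compound 2, which alters the same ring, cannot be read, and much of the set still sits at the ceiling: the limit of > 32500 nM in this assay, at which 2 of the 4 values shown sit.

On these data alone, whether the step belongs to trifluoromethyl itself or would also follow from a nitrile or an amine at this place remains open. So does whether it would carry over to compound 3, with its methyl on the oxygen.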